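Nitro for Methylsulfonyl on a P2X7 Antagonist Amide

This account rests on a few compounds, and the source may have more. Where it says the series, first, only, none or still open, it means among the compounds named here.

compound 1 `O=C(c1ccc([N+](=O)[O-])cc1)N1CCC(n2cncc2-c2ccc(OS(=O)(=O)c3cccc4cnccc34)cc2)CC1`: 1.49 nM
compound 2 `CS(=O)(=O)c1ccc(C(=O)N2CCC(n3cncc3-c3ccc(OS(=O)(=O)c4cccc(C#N)c4)cc3)CC2)cc1`: 143 nM

In an assay on HEK293 cells for antagonist activity at P2X purinoceptor 7 (Homo sapiens), read by fluorescence, with a stated time of 2 h (on this read-out lower numbers stand for stronger inhibition and higher numbers for weaker inhibition), compound 1 gives 1.49 nM and compound 2 gives 143 nM. Among the measured compounds shown here, compound 2 therefore has the higher of the two numbers; its only neighbour, compound 1, sits far lower, well beyond the scatter. The two compounds differ at two places at once, so that gap cannot be tied to a single change.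

Compound 3 `N#Cc1cccc(S(=O)(=O)Oc2ccc(-c3cncn3C3CCN(C(=O)c4ccc([N+](=O)[O-])cc4)CC3)cc2)c1` differs from compound 2 in one place only: nitro in place of methylsulfonyl on an aromatic carbon. For the measured compounds named here, no measured pair shows this change on its own. Compound 1 carries the same nitro group, but also a different aryl on the sulfonate, so it cannot tell what the nitro alone does. A modest step toward a lower number is expected, close to the edge of the scatter. Compound 3 is estimated at 60 nM, with a range from 15 nM to 250 nM. This estimate means an expected step of a 2.4-fold lower number from compound 2 to compound 3 (0.38 log units; beyond the scatter).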

Compound 3, half-maximal inhibitory concentration: 45 nM
Beside the measured number, compound 3's estimate is 1.3-fold (0.12 log units) above it, and the stated range covers the measured number.
By their numbers in this assay, from the lowest: compound 1; then compound 3; then compound 2.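

In this assay the change from 4-(methylsulfonyl)phenyl to 4-nitrophenyl can now be sized on its own, as a 3.2-fold lower number from compound 2 to compound 3 (0.50 log units; beyond the scatter) and a modest step toward stronger inhibition. Compound 3 also differs from compound 1 in one place only, and 3-cyanophenyl in place of isoquinolin-5-yl on the sulfonyl sulfur gives a 30-fold higher number from compound 1 to compound 3 (1.48 log units; beyond the scatter) in a large step toward weaker inhibition, so within these three compounds the sulfonate aryl matters far more than the amide aryl. Nothing measured on these compounds gives a reason for either step.

As far as these compounds go, it remains open whether nitro in place of methylsulfonyl would give a similar step with isoquinolin-5-yl on the sulfonyl sulfur. Also open, from the compounds shown here alone, is how other groups on the same aromatic carbon, such as an amine or a carboxylic acid, would compare.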